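The source may hold more compounds than are shown below. What is called first, only, known or untested is meant among the compounds shown, and "the series" means these compounds.

Measured so far:
compound 1, `O=C(Nc1ccccc1C(F)(F)F)C1CCc2ccccc2N1C(=O)c1ccccc1`; in a functional assay on NCI-H23 cells (Homo sapiens) for cytotoxicity, read by sulforhodamine B assay, with a stated time of 72 h (a higher number here means a weaker inhibitor of growth, a lower number a stronger inhibitor of growth), compound 1 gives 6340 nM
compound 2, `CCCCCCCCC(=O)N1c2ccccc2CCC1C(=O)Nc1ccccc1C(F)(F)F`; compound 2 gives 4220 nM
compound 3, `CC(=O)N1c2ccccc2CCC1C(=O)Nc1ccccc1C(F)(F)F`; for compound 3 only a limit is recorded, > 80000 nM

Compound 3 therefore sits at the limit of the assay the limit of > 80000 nM in this assay, at which 1 of the 3 values shown sits, and has no number of its own. Compound 4, `CCC(=O)N1c2ccccc2CCC1C(=O)Nc1ccccc1C(F)(F)F`, differs from compound 3 by methyl in place of hydrogen on a saturated chain carbon bound to a carbonyl carbon. Among the measured compounds shown here, the steps that bear on this are an at least 18-fold higher number from compound 2 to compound 3 (1.27 log units; beyond the scatter) and an at least 12-fold higher number from compound 1 to compound 3 (1.10 log units; beyond the scatter), both large, while a 1.5-fold lower number from compound 1 to compound 2 (0.18 log units; within the scatter) stays within the scatter. Because the added methyl is only a small part of the heptyl chain of compound 2 that gave an at least 18-fold higher number from compound 2 to compound 3 (1.27 log units; beyond the scatter), a lower number is expected for compound 4 in this assay, but only a modest one. Compound 4 is estimated at 60000 nM, range 15000 nM to 160000 nM, an expected step of an at least 1.3-fold lower number from compound 3 to compound 4 (0.12 log units; that floor lies within the scatter).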

Compound 4, concentration for 50% growth inhibition: > 80000 nM
Compound 4: a limit, no number; the forecaster's own chance of this, stated with the estimate: 40%; middle value at least 1.3-fold (0.12 log units) from the limit.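

Compound 4, like compound 3, gives a limit and not a number: the limit of > 80000 nM in this assay, at which 2 of the 4 values shown sit. The step between them therefore cannot be read, but in this assay the change from acetyl to propanoyl does not bring a measurable value. The ethyl on the carbonyl carbon stays well apart from the longer and aryl groups, with an at least 18-fold higher number from compound 2 to compound 4 (1.27 log units; beyond the scatter) and an at least 12-fold higher number from compound 1 to compound 4 (1.10 log units; beyond the scatter).

As far as these compounds go, whether a butyl or hexyl chain on that carbonyl carbon gives a measurable value remains open. So does the effect of an amine at the end of such a chain.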